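Swapping Trifluoromethyl for Cyano in a Series at the Limit

The source may report more compounds than this note shows. Statements on the series, on what has been measured and on what is new or still open speak of the compounds shown alone.

Compound 1 `CCN(CC)c1ccc(-c2cccc(OC)c2)nn1`: > 25000 nM
Compound 2 `CCN(CC)c1ccc(-c2cccc(Cl)c2)nn1`: > 25000 nM
Compound 3 `CCN(CC)c1ccc(-c2cccc(C(F)(F)F)c2)nn1`: > 25000 nM

In an ADME assay on cells (Fibroblast, Homo sapiens) for antiproliferative activity, with a stated time of 48 h (on this read-out lower numbers stand for stronger inhibition and higher numbers for weaker inhibition), compound 1 gives > 25000 nM, which is a limit of the assay rather than a number. Compound 2 gives > 25000 nM, also a limit. Compound 3 gives > 25000 nM, again a limit, so compound 3 stands at the limit of > 25000 nM in this assay, at which 3 of the 3 values shown sit. The steps a step that the two limits leave unreadable from compound 1 to compound 2, a step that the two limits leave unreadable from compound 1 to compound 3 and a step that the two limits leave unreadable from compound 2 to compound 3 therefore have no readable size. Compound 4 `CCN(CC)c1ccc(-c2cccc(C#N)c2)nn1` differs from compound 3 by cyano in place of trifluoromethyl on an aromatic carbon. The three measured steps bear on this change only by showing that every variation at this position stayed at the limit, so no step beyond the scatter is expected: a number no higher from compound 3 to compound 4 (the limit leaves the size open). Compound 4 is expected to give 25000 nM, between 8000 nM and 100000 nM, most likely reported only as a limit.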

Compound 4, half-maximal inhibitory concentration: > 25000 nM
Compound 4: only a limit was reported; the forecaster's own chance of this, stated with the estimate: 85%; the middle value lies on the limit itself.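

No step can be read from compound 4 to compound 1, compound 2 or compound 3, as all sit at one limit: the limit of > 25000 nM in this assay, at which 4 of the 4 values shown sit. The compounds shown leave open how far apart their true values lie.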